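A Methanesulfonamido Group Added to Compound 1

The source may report more compounds than this note shows. Statements on the series, on what has been measured and on what is new or still open speak of the compounds shown alone.

Measured compounds:
compound 1, `O=C(O)Cc1sc(C(c2ccc(F)cc2)c2ccc(F)cc2)nc1-c1ccccc1`, in an in vitro assay on HEK385-7 cells for displacement of a labelled ligand from prostaglandin D2 receptor 2 (Homo sapiens) (a lower number here means a stronger inhibitor, a higher number a weaker inhibitor), compound 1 gives 16 nM
compound 2, `O=C(O)Cc1sc(C(c2ccccc2)c2ccccc2)nc1-c1ccc(F)c(F)c1`, in this assay compound 2 gives 4.1 nM

For the measured compounds named here, of the two numbers known, compound 1 stands at the higher one. Compound 2 gives the lower number, and the gap between them is beyond the usual scatter; but the two compounds differ in more than one place, so the gap cannot be tied to any single change.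

Compound 3, `CS(=O)(=O)Nc1cccc(-c2nc(C(c3ccc(F)cc3)c3ccc(F)cc3)sc2CC(=O)O)c1`, differs from compound 1 in one place only: methanesulfonamido in place of hydrogen on an aromatic carbon. The change brings a hydrogen-bond donor and two acceptors onto the phenyl, meta to a large group, so that phenyl becomes 3-(methanesulfonamido)phenyl. Going by the values given here, no measured pair shows this change, so its effect is not known from the data.

Without such a pair, only a small step is expected from compound 1 to compound 3 in this assay, if any beyond the scatter, and it is estimated to be a 1.6-fold lower number from compound 1 to compound 3 (0.20 log units; within the scatter). Compound 3 is therefore expected to give about 10 nM, within a range from 3 nM to 35 nM.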

Compound 3, half-maximal inhibitory concentration: 40 nM
For compound 3 the middle estimate is 4.0-fold (0.60 log units) below the measured one; the whole stated range lies below it.
By their numbers in this assay, from the lowest: compound 2; then compound 1; then compound 3.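

In this assay, for the compounds shown here, the change of phenyl to 3-(methanesulfonamido)phenyl gives the first step that can be tied to a single place: a 2.5-fold higher number from compound 1 to compound 3 (0.40 log units; beyond the scatter), a modest step. It shows that this phenyl is not indifferent to what is placed on it, yet the effect of adding methanesulfonamido on this aromatic carbon is limited, and compound 3 still gives 40 nM in this assay. Nothing among the data shown accounts for the direction or the size of this step.

From the compounds shown here alone, one substitution cannot show whether the step follows from the methanesulfonamido group as a whole or from one of its parts, so it remains open how a simple amine, an acetamido group or a carboxylic acid on the same carbon would compare. Going by these compounds, it is also open whether the same change would give a similar step on compound 2, and the gap between compound 1 and compound 2 still cannot be assigned to any one of their differences.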